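Amide-side substituent variation in a kinase binding series

A few compounds are considered here, and "the series" means these few. Any claim that something is new, unique, unknown or untested is made for them only; others in the source may bear on it.

Measured so far:
compound 1 `CN(CCCn1ccnc1)C(=O)[C@@H]1CCCN1c1nccc(Nc2ccccc2)n1`: 0%
compound 2 `COC[C@@H]1CCCN1C(=O)[C@@H]1CCCN1c1nccc(Nc2ccccc2)n1`: 0%
compound 3 `Cc1cc(C(=O)N2CCN(c3ncnc4c3CN(Cc3ccccc3)CC4)CC2)c(C)n1C`: 0%

In an assay on isolated protein for inhibition of RAC-alpha serine/threonine-protein kinase (Homo sapiens), read by HTRF, tested at 10 uM (a higher number here means more inhibition at the concentration tested (going by the name of the read-out), a lower number less inhibition), compound 2 gives 0%, level with compounds 1 and 3 at the digits shown; none of the three separates from the others. Within the data shown here, the only single-change step measured, no change at the digits printed from compound 1 to compound 2 (within the scatter), replaced the group on the carbonyl carbon and stayed flat within the scatter. Compound 4 `CN(C)CC(C)(C)CNC(=O)[C@@H]1CCCN1c1nccc(Nc2ccccc2)n1` differs from compound 2 at that same position: (2-((dimethylamino)methyl)-2-methylpropyl)amino in place of 2-(methoxymethyl)pyrrolidin-1-yl on a carbonyl carbon. Compound 3 shares no single change with compound 2, so only the flat step bears here. Among the measured compounds shown here, since the one comparable change showed nothing, the step to compound 4 is expected to be a number 2 percentage points higher from compound 2 to compound 4 (within the scatter), i.e. none beyond the scatter. For compound 4 the estimate in this assay is 2%, expected between -10% and 15%.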

Compound 4, a percentage reported as inhibition, at one concentration (the size of the read-out at that concentration, not a potency): 0%
Compound 4: the middle estimate sits 2 percentage points above what was measured, and the stated range covers the measured number.
By their numbers in this assay, from the lowest: compounds 1, 2, 3 and 4 (each within the scatter of the next).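

In this assay, (2-((dimethylamino)methyl)-2-methylpropyl)amino on the carbonyl carbon gives no change at the digits printed from compound 2 to compound 4 (within the scatter) and no change at the digits printed from compound 1 to compound 4 (within the scatter). A group with no ring and a hydrogen-bond donor thus reads level with 2-(methoxymethyl)pyrrolidin-1-yl, which has a ring and no donor, so three different groups at this position do not separate. No supporting data bear on this flat result.

On these data alone, whether a carboxylic acid or an anilino group on this carbonyl carbon would raise the number remains open. So does whether any change to the shared core would.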